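Adding a Ring Nitrogen to a Fused Bicycle

This account rests on a few compounds, and the source may have more. Where it says the series, first, only, none or still open, it means among the compounds named here.

Compound 3 `CC(=O)N1CCC(n2cc(-c3cnc(N)c4oc(-c5csc6ccccc56)cc34)cn2)CC1` carries a 1-benzothiophen-3-yl group on the shared core. In an ADME assay on microsomes from liver (Mus musculus) for metabolic stability (on this read-out higher numbers stand for higher hepatic extraction and lower numbers for lower hepatic extraction), compound 3 gives 0.85, the second highest of three numbers. Compound 2 `CC(=O)N1CCC(n2cc(-c3cnc(N)c4oc(-c5cn(C)c6cnccc56)cc34)cn2)CC1` gives 0.91, and compound 1 `CC(=O)N1CCC(n2cc(-c3cnc(N)c4oc(-c5cccc6nnsc56)cc34)cn2)CC1` gives 0.7. Between them the steps were a number 0.060 lower from compound 2 to compound 3 (within the scatter), a number 0.15 higher from compound 1 to compound 3 (beyond the scatter) and a number 0.21 higher from compound 1 to compound 2 (beyond the scatter). Compound 4 `CC(=O)N1CCC(n2cc(-c3cnc(N)c4oc(-c5csc6cnccc56)cc34)cn2)CC1` differs from compound 3 in one place: a group of 9 heavy atoms (7 carbon, 1 nitrogen, 1 sulfur; one five-membered aromatic ring with 1 hetero atom, one six-membered aromatic ring with 1 hetero atom) in place of a group of 9 heavy atoms (8 carbon, 1 sulfur; one five-membered aromatic ring with 1 hetero atom, one six-membered aromatic ring of carbon only), on an aromatic carbon. Going by the values given here, the closest precedent is the step a number 0.060 lower from compound 2 to compound 3 (within the scatter), where a six-membered aromatic ring with one hetero atom likewise stood against one of carbon only, and that step fell within the scatter. The expected step is therefore a number 0.020 higher from compound 3 to compound 4 (within the scatter), essentially none beyond the scatter. The estimate for compound 4 is 0.87, within 0.75 to 0.96.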

Compound 4, hepatic extraction ratio: 0.72
Beside the measured number, compound 4's estimate is 0.15 above it; the measured number lies below the stated range.
By their numbers in this assay, from the lowest: compounds 1 and 4 (each within the scatter of the next); then compounds 3 and 2 (each within the scatter of the next).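

In this assay, going by these compounds alone, one ring nitrogen in the six-membered ring of the 1-benzothiophen-3-yl group gives a number 0.13 lower from compound 3 to compound 4 (beyond the scatter) and shows that a single ring atom in this group can matter, something the earlier compounds could not show. The new group also gives a number 0.19 lower from compound 2 to compound 4 (beyond the scatter) and a number 0.020 higher from compound 1 to compound 4 (within the scatter) and so joins the low end of the series. Nothing measured here explains these steps. Still open, from the compounds shown here alone, is how the number would respond to that ring nitrogen elsewhere in the six-membered ring. Also open, going by these compounds, is what a methoxy group or a fluorine on that ring would do.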